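An Ethyl Ester in Place of the Free Acid

The source may hold more compounds than are shown below. What is called first, only, known or untested is meant among the compounds shown, and "the series" means these compounds.

Compound 1, `CC(=O)Nc1cccc(-c2ccc(C(=O)N(Cc3cccc(OCCCCCC(=O)O)c3)C(C)C)cc2)c1`, is reported in an ADME assay on BJ cells (Homo sapiens) for cytotoxicity, read by CellTiter-Glo and resazurin assay, with a stated time of 72 h (a lower number here means that less compound is needed, a higher number that more compound is needed for the effect), only as a limit of > 26000 nM.
Compound 2, `CC(C)N(Cc1cccc(OCCCCCC(=O)O)c1)C(=O)c1ccc(-c2cccc(-c3ccccc3)c2)cc1`, is reported in this assay only as a limit of > 26000 nM.
Compound 3, `CC(C)N(Cc1cccc(OCCCCCC(=O)O)c1)C(=O)c1ccc(-c2cccc(O)c2)cc1`, is reported in this assay only as a limit of > 26000 nM.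

All three values sit at the same limit (the limit of > 26000 nM in this assay, at which 3 of the 3 values shown sit), so compound 2 stands level with the others and no ordering can be read. The measured steps a step that the two limits leave unreadable from compound 1 to compound 2, a step that the two limits leave unreadable from compound 1 to compound 3 and a step that the two limits leave unreadable from compound 2 to compound 3 all concern a group on an aromatic carbon and are unreadable; none touches the acid end. Compound 4, `CCOC(=O)CCCCCOc1cccc(CN(C(=O)c2ccc(-c3cccc(-c4ccccc4)c3)cc2)C(C)C)c1`, differs from compound 2 by ethyl in place of hydrogen on an oxygen next to a carbonyl group. Among the measured compounds shown here, no measured step speaks to this change, so the step from compound 2 to compound 4 is expected to be a number no higher from compound 2 to compound 4 (the limit leaves the size open), within the scatter. Compound 4 is therefore estimated at 26000 nM, between 8000 nM and 60000 nM, most likely again reported only as a limit.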

Compound 4, half-maximal effective concentration: > 26000 nM
Compound 4: no number, only a limit (the forecaster's own chance of this, stated with the estimate: 70%); the middle value lies on the limit itself.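

Compound 4, like compound 2, is reported only as a limit, so the step between them cannot be read: the limit of > 26000 nM in this assay, at which 4 of the 4 values shown sit.

The compounds shown leave open whether the ethyl ester or any other change here shifts the half-maximal effective concentration in this assay.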